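From 3-Methylphenyl to 2,5-Dimethylphenyl

A few compounds are considered here, and "the series" means these few. Any claim that something is new, unique, unknown or untested is made for them only; others in the source may bear on it.

Compound 1 `COc1cccc(NS(=O)(=O)c2ccc(N3CCNC3=O)cc2)c1` and compound 2 `Cc1cccc(NS(=O)(=O)c2ccc(N3CCNC3=O)cc2)c1` share one core and differ in a single group. In a functional assay on CCRF-CEM cells (Homo sapiens) for antiproliferative activity, read by sulforhodamine B assay, with a stated time of 48 h (a higher number here means a weaker inhibitor, a lower number a stronger inhibitor), compound 1 gives 260 nM, and compound 2 gives 200 nM; the step of a 1.3-fold lower number from compound 1 to compound 2 (0.11 log units; within the scatter) lies within the scatter. Compound 2 stands at the lowest of the two numbers measured, though its gap to compound 1 is within the scatter. Compound 3 `Cc1ccc(C)c(NS(=O)(=O)c2ccc(N3CCNC3=O)cc2)c1` carries one more change: methyl in place of hydrogen on an aromatic carbon. Among the measured compounds shown here, only the step from compound 1 to compound 2 bears on this, and it was small. The number for compound 3 is therefore expected to stay close, an estimated step of a 1.1-fold lower number from compound 2 to compound 3 (0.05 log units; within the scatter). Compound 3 is estimated at 180 nM, with a range from 80 nM to 450 nM.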

Compound 3, half-maximal inhibitory concentration: 74 nM
The estimate for compound 3 lay 2.4-fold (0.39 log units) above the measured number, and the stated range ends above it.
By their numbers in this assay, from the lowest: compound 3; then compounds 2 and 1 (each within the scatter of the next).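

In this assay, a methyl group in place of hydrogen at this position, ortho to a large group and para to a methyl group, gives a 2.7-fold lower number from compound 2 to compound 3 (0.43 log units; beyond the scatter), so this change moves the number beyond the scatter, as methyl in place of methoxy did not. Across the whole group on the sulfonamide nitrogen, 2,5-dimethylphenyl in place of 3-methoxyphenyl gives a 3.5-fold lower number from compound 1 to compound 3 (0.55 log units; beyond the scatter). No evidence at hand accounts for this step.

The compounds shown leave open whether an ethyl group or a chlorine atom at this position would lower the number as well. They also leave open what an amine there would do.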